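Dropping the chloro group from a diaryl imine

This account rests on a few compounds, and the source may have more. Where it says the series, first, only, none or still open, it means among the compounds named here.

Measured compounds:
compound 1 `COc1ccc(/C=C/c2ccc(C)cc2)cc1`: > 200 ug/mL, a limit of the assay
compound 2 `Fc1ccc(/N=C/c2ccccc2Cl)cc1Cl`: 3.9 ug/mL
compound 3 `Fc1ccc(/C=C/c2ccccc2F)cc1`: 61 ug/mL

In a functional assay on MOLT-4 cells (Homo sapiens), read by cell counting, with a stated time of 72 h (on this read-out higher numbers stand for weaker inhibition and lower numbers for stronger inhibition), compound 2 gives the lowest of the two numbers that were obtained. Compound 3 sits well apart from it, with a number higher by a gap that lies beyond the scatter of repeated measurements. Compound 1 gives only a limit in this assay and no number; this is the point described by the limit of > 200 ug/mL in this assay, at which 1 of the 3 values shown sits.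

Compound 4 `Fc1ccc(/N=C/c2ccccc2Cl)cc1` is the analogue of compound 2 that has not yet been measured in this assay. It differs by hydrogen in place of chloro on an aromatic carbon, the carbon in question being ortho to a fluoro group and meta to a group of 9 heavy atoms. Among the measured compounds shown here, no pair among the measured compounds differs at exactly this position, so the size of the step can only be guessed. Compound 4 is expected to be somewhat weaker, with a step of a 2.6-fold higher number from compound 2 to compound 4 (0.41 log units; beyond the scatter). The estimate for compound 4 is therefore 10 ug/mL, with a likely range from 3 ug/mL to 40 ug/mL.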

Compound 4, half-maximal inhibitory concentration: 0.77 ug/mL
For compound 4 the middle estimate is 13-fold (1.11 log units) above the measured one, and the stated range ends above it.
By their numbers in this assay, from the lowest: compound 4; then compound 2; then compound 3. At a limit, above all of these: compound 1.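

In this assay, putting hydrogen in place of chloro on this aromatic carbon, ortho to a fluoro group and meta to a group of 9 heavy atoms, gives a 5.1-fold lower number from compound 2 to compound 4 (0.70 log units; beyond the scatter). Among the compounds shown here, this is the first step read at this position, and it shows that the chloro group is not required for inhibition here: the change strengthens inhibition rather than weakening it. No measurement shown bears on why removing this one heavy atom has that effect.

The compounds shown leave open whether another replacement on this carbon, such as bromo, an amine or a hydroxyl group, would move the number in the same direction. They also leave open what the chloro group that compound 4 keeps contributes.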